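Chlorine Moved on the Benzyl Ring: A Growth Inhibition Estimate

This account rests on a few compounds, and the source may have more. Where it says the series, first, only, none or still open, it means among the compounds named here.

Measured so far:
compound 1 `COc1cccc(OC)c1OCCNCCOc1ccccc1OCc1ccccc1`: 76900 nM
compound 2 `COc1cccc(OC)c1OCCNCCOc1ccccc1OCc1ccccc1Cl`: 17800 nM

In a functional assay on PC-3 cells (Homo sapiens) for cytotoxicity, read by sulforhodamine B assay (on this read-out higher numbers stand for weaker inhibition of growth and lower numbers for stronger inhibition of growth), compound 1 gives 76900 nM, the highest of the two numbers; the nearest is compound 2 at 17800 nM. Compound 3 `COc1cccc(OC)c1OCCNCCOc1ccccc1OCc1cccc(Cl)c1` differs from compound 1 by chloro in place of hydrogen on an aromatic carbon. Among the compounds with values here, the one step that bears on this is a 4.3-fold lower number from compound 1 to compound 2 (0.64 log units; beyond the scatter), where the chlorine sat on the same benzyl ring. A chlorine at a different place on that ring is expected to lower the number by a smaller amount, giving an expected 2.6-fold lower number from compound 1 to compound 3 (0.41 log units; beyond the scatter). Compound 3 is therefore estimated at 30000 nM, between 12000 nM and 77000 nM.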

Compound 3, concentration for total growth inhibition: 20400 nM
The estimate for compound 3 lay 1.5-fold (0.17 log units) above the measured number; the range from low to high includes it.
By their numbers in this assay, from the lowest: compounds 2 and 3 (each within the scatter of the next); then compound 1.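

In this assay the 3-chlorobenzyl group also improves on plain benzyl, with a 3.8-fold lower number from compound 1 to compound 3 (0.58 log units; beyond the scatter) and thus a gain that does not depend on a single chlorine place on this ring. The two chlorinated compounds stand level, with a 1.1-fold higher number from compound 2 to compound 3 (0.06 log units; within the scatter) and no preference between 3-chlorophenyl and 2-chlorophenyl on this read-out.

On these data alone, whether a fluoro or a methoxy group in place of the chloro would give a similar number remains open. No supporting evidence is available to explain what the chloro does here.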